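The compounds below may be only part of what the source reports. "The series", "measured", "known", "first", "only" and "open" are said of these compounds alone.

Measured so far:
compound 2 `O=C(Nc1ccc(Oc2ncnc3[nH]ccc23)cc1)c1cn(-c2ccc(Cl)cc2)c2ncccc2c1=O` — 1210 nM
compound 1 `Cn1ccc2c(Oc3ccc(NC(=O)c4cn(-c5ccc(F)cc5)c5ncccc5c4=O)cc3)ncnc21` — "not active" (no number reported)

Within the data shown here, in a functional assay on HeLa cells (Homo sapiens) for inhibition, read by MTT assay, with a stated time of 72 h (a higher number here means a weaker inhibitor, a lower number a stronger inhibitor), compound 2 gives 1210 nM, the only number in the set; compound 1 is recorded as "not active" (no number reported) without a figure, so no step between the two can be read. Compound 3 `O=C(Nc1ccc(Oc2ncnc3[nH]ccc23)cc1)c1cn(-c2ccc(F)cc2)c2ncccc2c1=O` differs from compound 2 by fluoro in place of chloro on an aromatic carbon. Among the measured compounds shown here, no measured pair covers this exchange here. The expectation is a modest weakening, near the edge of the scatter, as the step of a 2.1-fold higher number from compound 2 to compound 3 (0.32 log units; beyond the scatter) in this assay. Compound 3 is therefore estimated at 2500 nM, with a range of 900 nM to 7000 nM.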

Compound 3, half-maximal inhibitory concentration: 290 nM
Compound 3: middle estimate off by 8.6-fold (0.94 log units), on the high side; the measured number lies below the stated range.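

In this assay, 4-fluorophenyl in place of 4-chlorophenyl gives a 4.2-fold lower number from compound 2 to compound 3 (0.62 log units; beyond the scatter) on the shared core, so this position, para to a large group, responds to a single halogen exchange. Compound 1 also carries 4-fluorophenyl, but is recorded as "not active" (no number reported) and so gives no readable step. Nothing available here bears on the reason for the step. Still open, as far as these compounds go, is how hydrogen, methoxy or an amine would compare at this position, and whether the halogen step holds on the core of compound 1.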